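Holding clearance low when bromo gives way to amino

A few compounds are considered here, and "the series" means these few. Any claim that something is new, unique, unknown or untested is made for them only; others in the source may bear on it.

- compound 1 `FC(F)(F)c1nccc(N[C@H]2CC[C@@H](Nc3ncnc4sccc34)CC2)n1`: 22 mL.min-1.g-1
- compound 2 `FC(F)(F)c1nccc(N[C@H]2CC[C@@H](Nc3ccc4ncc(Cl)n4n3)CC2)n1`: 9.9 mL.min-1.g-1
- compound 3 `FC(F)(F)c1nccc(N[C@H]2CC[C@@H](Nc3ccc4nnc(Br)n4n3)CC2)n1`: < 3 mL.min-1.g-1

In an ADME assay on microsomes from liver (Homo sapiens) for metabolic stability, read by LC-MS (a higher number here means faster removal of the compound, a lower number slower removal), compound 3 gives < 3 mL.min-1.g-1, which is a limit and not a number. Compound 1 and compound 2 both return actual numbers, each higher than that limit. Compound 4 `Nc1nnc2ccc(N[C@H]3CC[C@@H](Nc4ccnc(C(F)(F)F)n4)CC3)nn12` carries amino in place of bromo on an aromatic carbon, on a five-membered aromatic ring with 3 nitrogen, between two ring nitrogen atoms. Among the measured compounds shown here, no measured pair shows this change, so the expectation in this assay is a step in neither direction beyond the scatter. The expected change is a number no lower from compound 3 to compound 4 (the limit leaves the size open). Compound 4 is expected at 3 mL.min-1.g-1, with an estimated range from 1.5 mL.min-1.g-1 to 8 mL.min-1.g-1.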

Compound 4, intrinsic clearance in microsomes: < 3 mL.min-1.g-1
Compound 4: no number, only a limit; the forecaster's own chance of this, stated with the estimate: 55%; the middle value lies on the limit itself.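

Compound 3 and compound 4 both return only a limit in this assay, so no step between them can be read: the limit of < 3 mL.min-1.g-1 in this assay, at which 2 of the 4 values shown sit.

Going by these compounds, whether amino in place of bromo changes intrinsic clearance at all, and by how much, stays open.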